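A Fluoro Group Gives Way to Hydroxy

The source may report more compounds than this note shows. Statements on the series, on what has been measured and on what is new or still open speak of the compounds shown alone.

Compound 1 `C=C1C=CC(=O)[C@@H]2[C@H](Cc3cc(OC)c(OC)c(OC)c3)CC[C@H]12`: > 1000 nM
Compound 2 `C=C1C=CC(=O)[C@@H]2[C@H](Cc3ccc(F)c(F)c3)CC[C@H]12`: 428 nM

Going by the values given here, in a functional assay on COLO 205 cells (Homo sapiens) for antiproliferative activity, with a stated time of 72 h (a higher number here means a weaker inhibitor, a lower number a stronger inhibitor), compound 2 gives 428 nM, the only true number among the measured compounds. Compound 1 reads > 1000 nM, which is a limit and not a number.

The next compound to be tested is compound 3 `C=C1C=CC(=O)[C@@H]2[C@H](Cc3ccc(O)c(F)c3)CC[C@H]12`, which differs from compound 2 in a single place: hydroxy in place of fluoro on an aromatic carbon. Hydroxy stands in place of fluoro on an aromatic carbon, ortho to a remaining fluoro group and para to a large group. Among the compounds with values here, no measured pair shows what this exchange does, so the expectation rests on compound 2 at 428 nM and on the structural change alone. A small move toward weaker inhibition in this assay is expected, and it may well stay within the usual scatter. The expected change is a 1.3-fold higher number from compound 2 to compound 3 (0.11 log units; within the scatter). The estimate for compound 3 is 550 nM, with an expected range of 200 nM to 1500 nM.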

Compound 3, half-maximal inhibitory concentration: 3000 nM
The estimate for compound 3 lay 5.5-fold (0.74 log units) below the measured number, outside the stated range (above it).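

In this assay the exchange of fluoro for hydroxy gives a 7.0-fold higher number from compound 2 to compound 3 (0.85 log units; beyond the scatter) and so provides the first measured read on this change, on an aromatic carbon ortho to a fluoro group and para to a large group. The position is thus not indifferent to what stands on it: only one heavy atom is exchanged, a hydrogen-bond donor and a hydrogen-bond acceptor enter where the fluoro group counted neither, and inhibition weakens beyond the scatter. Of this pair, compound 2 with its two fluoro groups is the stronger inhibitor, so at this position fluoro is the better of the two groups tested.

Going by these compounds, whether an amine or a chloro group on the same aromatic carbon would read closer to compound 2 or to compound 3 stays open, as does whether the remaining fluoro group has any part in the size of the step. Nothing measured among the compounds shown accounts for the loss seen with hydroxy.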